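The source may report more compounds than this note shows. Statements on the series, on what has been measured and on what is new or still open speak of the compounds shown alone.

Measured so far:
compound 1, `FC(F)(F)c1ccc(CN2CCN(Cc3cc(-c4ccc(OCc5ccccc5)cc4)on3)CC2)cc1`: in a functional assay on Mahlavu cells (Homo sapiens) for antiproliferative activity, read by sulforhodamine B assay, with a stated time of 72 h (a higher number here means a weaker inhibitor, a lower number a stronger inhibitor), compound 1 gives 11700 nM.
compound 2, `Cc1ccc(COc2ccc(-c3cc(CN4CCN(Cc5ccc(C(F)(F)F)cc5)CC4)no3)cc2)cc1`: in this assay compound 2 gives 7500 nM.

For the measured compounds named here, of the two numbers, that of compound 2 is the smaller, but the single measured step, a 1.6-fold lower number from compound 1 to compound 2 (0.19 log units; within the scatter), is within the scatter, so the two compounds are not distinguished on what is known.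

Compound 3, `FC(F)(F)c1ccc(CN2CCN(Cc3cc(-c4ccc(OCc5ccc(Cl)cc5)cc4)on3)CC2)cc1`, is not yet measured. It differs from compound 2 by chloro in place of methyl on an aromatic carbon. Going by the values given here, the only measured step sits at the same aromatic carbon: a 1.6-fold lower number from compound 1 to compound 2 (0.19 log units; within the scatter), a change from hydrogen to methyl that stayed within the scatter. Among the compounds with values here, no measured step involves chloro anywhere, so the exchange of methyl for chloro has no direct precedent here. Given that the one change at this position left the number essentially unmoved, the expectation for compound 3 in this assay is a step of a 1.1-fold lower number from compound 2 to compound 3 (0.03 log units; within the scatter), not beyond the scatter in either direction. The estimated value for compound 3 is 7000 nM, with a range of 3500 nM to 14000 nM.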

Compound 3, half-maximal inhibitory concentration: 3700 nM
For compound 3 the middle estimate is 1.9-fold (0.28 log units) above the measured one, within the range that was stated.
By their numbers in this assay, from the lowest: compound 3; then compounds 2 and 1 (each within the scatter of the next).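

In this assay this position gives its first steps beyond the scatter, both modest: with chloro in place of methyl (a 2.0-fold lower number from compound 2 to compound 3 (0.31 log units; beyond the scatter)) and with chloro in place of hydrogen (a 3.2-fold lower number from compound 1 to compound 3 (0.50 log units; beyond the scatter)). The number therefore does respond to the group on this aromatic carbon, although methyl in place of hydrogen (a 1.6-fold lower number from compound 1 to compound 2 (0.19 log units; within the scatter)) stayed within the scatter, so the response so far belongs to chloro alone among the three groups, and compound 3 holds the lowest number of the series. The exchange swaps one heavy atom for one heavy atom, with no hydrogen-bond donor or acceptor on either side, and nothing at hand accounts for the difference between chloro and methyl at this position.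

The compounds shown leave open whether a bromo or a methoxy group on this aromatic carbon would match, exceed or lose the step seen with chloro, and whether chloro keeps that step on another carbon of the same ring. They also leave open whether the step survives when the trifluoromethyl group is exchanged for a nitrile.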